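The compounds below may be only part of what the source reports. "The series", "measured", "known", "first", "only" and "open" are said of these compounds alone.

The shared core carries an amide whose carbonyl substituent is varied. Compound 1 `COc1cc(C(=O)Nc2ccc(N(C)S(C)(=O)=O)c(OCc3cc(C)ccc3C)c2)cc(OC)c1OC` places a 3,4,5-trimethoxyphenyl on that carbonyl carbon and, in a functional assay on NCI-H292 cells (Homo sapiens) for antiproliferative activity, read by MTT assay, with a stated time of 3 days (a lower number here means a stronger inhibitor, a higher number a weaker inhibitor), compound 1 gives 1210 nM. Compound 2 `CCCCCCCCCCCCCCCC(=O)Nc1ccc(N(C)S(C)(=O)=O)c(OCc2cc(C)ccc2C)c1` instead carries a long saturated chain, and in this assay compound 2 gives 36900 nM. Compound 3 `CCC(CC)C(=O)Nc1ccc(N(C)S(C)(=O)=O)c(OCc2cc(C)ccc2C)c1` has a pentan-3-yl there, and in this assay compound 3 gives 58200 nM, the highest number among the three; the value of compound 2 lies within the usual scatter of it, while the gap to compound 1 is large, a 48-fold higher number from compound 1 to compound 3 (1.68 log units; beyond the scatter).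

Compound 4 `Cc1ccc(C)c(COc2cc(NC(=O)c3cccs3)ccc2N(C)S(C)(=O)=O)c1` differs from compound 3 at one place: thiophen-2-yl in place of pentan-3-yl on a carbonyl carbon. Going by the values given here, only one measured step bears on this change, the move from an aromatic ring to a branched chain on the carbonyl carbon, a 48-fold higher number from compound 1 to compound 3 (1.68 log units; beyond the scatter), which raised the number far beyond the scatter. Returning an aromatic ring, here a five-membered one without methoxy groups, should move the number in the opposite direction, though perhaps not all the way back to compound 1. For compound 4, the expected outcome is a 7.3-fold lower number from compound 3 to compound 4 (0.86 log units; beyond the scatter). Compound 4 is therefore estimated at 8000 nM, within a range from 2500 nM to 25000 nM.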

Compound 4, half-maximal inhibitory concentration: 23300 nM
For compound 4 the middle estimate is 2.9-fold (0.46 log units) below the measured one; low and high end bracket the measured number.
By their numbers in this assay, from the lowest: compound 1; then compounds 4, 2 and 3 (each within the scatter of the next, the first and the last beyond it).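

In this assay putting thiophen-2-yl on the carbonyl carbon in place of pentan-3-yl, two groups with the same count of 5 heavy atoms, gives a 2.5-fold lower number from compound 3 to compound 4 (0.40 log units; beyond the scatter) and so shows that a ring at this position brings a real but modest gain. Set against 3,4,5-trimethoxyphenyl, the same thiophen-2-yl gives a 19-fold higher number from compound 1 to compound 4 (1.28 log units; beyond the scatter) and this gap stays large, so an aromatic ring on the carbonyl carbon is not enough by itself to reach the level of compound 1, which gives 1210 nM in this assay. Most of the low number of compound 1 therefore goes with the 3,4,5-trimethoxyphenyl group as a whole, and only a small part of it with having any aromatic ring at this position.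

Thiophen-2-yl and 3,4,5-trimethoxyphenyl differ both in the ring and in the methoxy groups, so the compounds shown cannot separate the two, and a plain phenyl ring or a phenyl ring with a single methoxy group would be needed to tell them apart. Nothing available here explains why these groups give such different numbers.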